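Sulfur substituent step from compound 3 to compound 4

The source may hold more compounds than are shown below. What is called first, only, known or untested is meant among the compounds shown, and "the series" means these compounds.

Values in a functional assay on HCT-116 cells (Homo sapiens) for inhibition, read by MTT assay, with a stated time of 48 h; on this read-out higher numbers stand for weaker inhibition and lower numbers for stronger inhibition:
- compound 1 `COc1cc(-c2nnc(S)n2-c2ccc(N(C)C)cc2)cc(OC)c1OC`: > 60000 nM (a limit, not a number)
- compound 2 `COc1cc(-c2nnc(SC)n2-c2ccc(N(C)C)cc2)cc(OC)c1OC`: > 60000 nM (a limit, not a number)
- compound 3 `COc1ccc(CSc2nnc(-c3cc(OC)c(OC)c(OC)c3)n2-c2ccc(N(C)C)cc2)cc1`: 1150 nM

Going by the values given here, compound 3 is the only compound here with an actual number. The other two compounds both stand at the limit of > 60000 nM in this assay, at which 2 of the 3 values shown sit.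

Compound 4 `COc1cc(-c2nnc(SCC(=O)c3ccccc3)n2-c2ccc(N(C)C)cc2)cc(OC)c1OC` keeps the shared core and changes the group on sulfur: benzoyl in place of 4-methoxyphenyl on a saturated chain carbon bound to a sulfur. In words, benzoyl replaces 4-methoxyphenyl on a saturated chain carbon bound to a sulfur.

Among the compounds with values here, two measured steps bear on this: an at least 52-fold lower number from compound 1 to compound 3 (1.71 log units; beyond the scatter) and an at least 52-fold lower number from compound 2 to compound 3 (1.71 log units; beyond the scatter). Both are large and beyond the scatter. The remaining step is a step that the two limits leave unreadable from compound 1 to compound 2, so it adds nothing. Among these three compounds, only the one with an aromatic ring on the sulfur chain gives a number, and compound 4 keeps such a ring. Within the data shown here, no measured compound carries a benzoyl, so the size of this step remains uncertain. A modest rise from compound 3 at 1150 nM is expected in this assay. A return to the limit is not expected.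

The estimated step is a 2.2-fold higher number from compound 3 to compound 4 (0.34 log units; beyond the scatter). For compound 4 the expected value is 2500 nM, with an estimated range of 500 nM to 15000 nM.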

Compound 4, half-maximal inhibitory concentration: 42500 nM
For compound 4 the middle estimate is 17-fold (1.23 log units) below the measured one, and the stated range ends below it.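

In this assay, keeping an aromatic ring on the sulfur chain does not by itself hold the activity of compound 3: benzoyl in place of 4-methoxyphenyl gives a 37-fold higher number from compound 3 to compound 4 (1.57 log units; beyond the scatter), although the two groups match in heavy atoms and hydrogen-bond acceptors. Against the compounds with no ring on sulfur, the readings are an at least 1.4-fold lower number from compound 2 to compound 4 (0.14 log units; that floor lies within the scatter) and an at least 1.4-fold lower number from compound 1 to compound 4 (0.14 log units; that floor lies within the scatter), so the ring-bearing chain of compound 4 shows no firm gain over either. Compound 1 and compound 2 remain limits, not numbers: the limit of > 60000 nM in this assay, at which 2 of the 4 values shown sit.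

Still open, as far as these compounds go, is whether the loss follows the added carbonyl or the missing methoxy, as the change brings both at once; benzyl and 4-methoxybenzoyl on a sulfur would separate the two. From the compounds shown here alone, the response to an amine or a carboxylic acid on the sulfur chain also remains unknown.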